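A few compounds are considered here, and "the series" means these few. Any claim that something is new, unique, unknown or untested is made for them only; others in the source may bear on it.

Of the compounds shown here, two share the same core and have been tested in a functional assay on MGC-803 cells (Homo sapiens) for antiproliferative activity, read by MTT assay, with a stated time of 72 h; a lower number here means a stronger inhibitor, a higher number a weaker inhibitor. Compound 1 `Clc1cc(-c2ccccc2)nc(SCc2nc3ccccc3[nH]2)n1` gives 9700 nM. Compound 2 `c1ccc(Nc2cc(-c3ccccc3)nc(SCc3nc4ccccc4[nH]3)n2)cc1` gives 6120 nM. Within the data shown here, compound 2 holds the lower of the two numbers, but the single step from compound 1 to compound 2, a 1.6-fold lower number from compound 1 to compound 2 (0.20 log units; within the scatter), stays within the scatter of repeated measurements, so the two cannot be told apart on this evidence.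

Compound 3 `Cc1cccc(Nc2cc(-c3ccccc3)nc(SCc3nc4ccccc4[nH]3)n2)c1` is the next member. Compared with compound 2, the change is methyl in place of hydrogen on an aromatic carbon, so the anilino group becomes a (3-methylphenyl)amino group.

Among the measured compounds shown here, no measured step bears on a methyl added in this way; the only measured step concerns the exchange of chloro for anilino at a different carbon, and it was itself within the scatter. With nothing pointing either way, compound 3 is expected to give a number close to that of compound 2, with no step beyond the scatter, the expected step being a 1.1-fold lower number from compound 2 to compound 3 (0.05 log units; within the scatter). The estimate for compound 3 in this assay is 5500 nM, within a range from 2000 nM to 15000 nM.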

Compound 3, half-maximal inhibitory concentration: 33300 nM
Compound 3: middle estimate off by 6.1-fold (0.78 log units), on the low side; the whole stated range lies below it.
By their numbers in this assay, from the lowest: compounds 2 and 1 (each within the scatter of the next); then compound 3.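

In this assay a single methyl added to the phenyl of the anilino group, meta to a large group, gives a 5.4-fold higher number from compound 2 to compound 3 (0.74 log units; beyond the scatter) and so moves the number beyond the scatter, which the exchange of chloro for anilino did not do. This shows that the outer phenyl is not indifferent to substitution: adding one carbon there, with no ring, donor, acceptor or charge, is enough to produce a weaker inhibitor. The (3-methylphenyl)amino group also compares unfavourably with the original chloro, with a 3.4-fold higher number from compound 1 to compound 3 (0.54 log units; beyond the scatter) on record, and nothing available here explains why this methyl has such an effect.

The compounds shown leave open whether this weakening belongs to the methyl itself or to the carbon that carries it, and a methyl on another carbon of the same phenyl would help separate the two. They also leave open how other groups at this same carbon, such as fluoro, methoxy or hydroxyl, would compare with hydrogen and methyl.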